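The source may report more compounds than this note shows. Statements on the series, on what has been measured and on what is new or still open speak of the compounds shown alone.

Working notes on the series.

Compound 1 `O=C(Nc1cccc(-n2cc(-c3ccncc3)c(-c3ccc(Cl)c(O)c3)n2)c1)Nc1cccc(C(F)(F)F)c1` gives 13700 nM in a functional assay on OVCAR-5 cells (Homo sapiens) for inhibition, read by sulforhodamine B assay, with a stated time of 48 h; a higher number here means a weaker inhibitor of growth, a lower number a stronger inhibitor of growth. Going by the values given here, compound 2 `O=C(Nc1cccc(-n2cc(-c3ccncc3)c(-c3ccc(Cl)c(O)c3)n2)c1)Nc1ccc(Cl)c(Cl)c1` gives 2400 nM, and the change a 5.7-fold lower number from compound 1 to compound 2 (0.76 log units; beyond the scatter) is the only single-point step measured so far. Compound 3 `COc1cc(-c2nn(-c3cccc(NC(=O)Nc4ccc(Cl)c(C(F)(F)F)c4)c3)cc2-c2ccncc2)ccc1Cl` gives 3090 nM and stands second highest of the three numbers; its nearest neighbour is compound 2, within the scatter, and compound 1 sits furthest away, beyond the scatter.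

Compound 4 `O=C(Nc1cccc(-n2cc(-c3ccncc3)c(-c3ccc(Cl)c(O)c3)n2)c1)Nc1ccc(Cl)c(C(F)(F)F)c1` is not yet measured. It differs from compound 3 by hydrogen in place of methyl on an oxygen on an aromatic ring. Among the compounds with values here, no measured step covers this change: compound 2 and compound 3 differ both at the aromatic oxygen and on the urea-bound phenyl, and their values show no separation beyond the scatter. Within the data shown here, the only measured step, from compound 1 to compound 2, concerns the urea-bound phenyl and not the oxygen. Among the measured compounds shown here, its size is modest, and nothing among the measured compounds links the aromatic oxygen substituent to a move in growth inhibition. The expectation is therefore a step of a 1.1-fold lower number from compound 3 to compound 4 (0.04 log units; within the scatter) that stays within the scatter, in no particular direction.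

Compound 4 is estimated at 2800 nM, with a range of 900 nM to 9000 nM.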

Compound 4, concentration for 50% growth inhibition: 1570 nM
Compound 4: the middle estimate sits 1.8-fold (0.25 log units) above what was measured; low and high end bracket the measured number.
By their numbers in this assay, from the lowest: compounds 4, 2 and 3 (each within the scatter of the next); then compound 1.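

In this assay, going by these compounds alone, methoxy to hydroxy on the 4-chloro-3-substituted phenyl gives a 2.0-fold lower number from compound 3 to compound 4 (0.29 log units; within the scatter), the first direct reading of this oxygen position, and at this value hydrogen and methyl on the oxygen are not told apart. The same compound settles two points on the urea-bound phenyl: trifluoromethyl in place of chloro on an aromatic carbon gives a 1.5-fold lower number from compound 2 to compound 4 (0.18 log units; within the scatter), which does not separate the two groups, while chloro in place of hydrogen on an aromatic carbon gives an 8.7-fold lower number from compound 1 to compound 4 (0.94 log units; beyond the scatter), so of these three steps only the last moves the number beyond the scatter. Nothing available gives a reason for any of these readings.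

Open, going by these compounds, is whether any group other than hydrogen or methyl on that oxygen, such as ethyl or a longer chain, or an amine in place of the oxygen, would shift growth inhibition beyond the scatter. Also open, on these data alone, is whether the oxygen reading carries over to other urea-bound phenyls, since methoxy appears here with only one of them, and whether a nitrile in place of chloro or trifluoromethyl on an aromatic carbon of that phenyl would read the same.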